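The compounds below may be only part of what the source reports. "The series", "measured", "known", "first", "only" and "open" are said of these compounds alone.

Three compounds have been measured in a functional assay on MDA-MB-231 cells (Homo sapiens) for inhibition, read by MTT assay and WST assay, with a stated time of 72 h, tested at 10 uM; on this read-out higher numbers stand for more inhibition of growth at the one concentration tested and lower numbers for less inhibition of growth:

Compound 1, `O=C(Nc1ccc(Oc2ccc(-c3nccs3)cc2)cc1)Nc1ccc(Cl)c([N+](=O)[O-])c1`, gives 72.8%.
Compound 2, `O=C(Nc1ccc(Oc2ccc(-c3nccs3)cc2)cc1)Nc1cccc(C(F)(F)F)c1`, gives 64.1%.
Compound 3, `O=C(Nc1ccc(Oc2ccc(-c3ncc[nH]3)cc2)cc1)Nc1ccc(Cl)c([N+](=O)[O-])c1`, gives 3.36%.

Compounds 1 and 2 share one core and differ only at one end of the urea: 3-(trifluoromethyl)phenyl in place of 4-chloro-3-nitrophenyl on an amide-type nitrogen. This change makes a number 8.7 percentage points lower from compound 1 to compound 2 (within the scatter), so the two numbers cannot be told apart by this assay. Compound 3 carries a different core, and the difference from compound 1 is counted as 1H-imidazol-2-yl in place of 1,3-thiazol-2-yl on an aromatic carbon. This change makes a number 69.4 percentage points lower from compound 1 to compound 3 (beyond the scatter), and compound 3 stands lowest of the three, beyond the scatter from both others.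

Compound 4, `O=C(Nc1ccc(Oc2ccc(-c3ncc[nH]3)cc2)cc1)Nc1cccc(C(F)(F)F)c1`, has not yet been measured. It stands to compound 3 as compound 2 stands to compound 1: 3-(trifluoromethyl)phenyl in place of 4-chloro-3-nitrophenyl on an amide-type nitrogen. The place is the same in both pairs, so this is the same change, seen now for the second time among these compounds. Within the data shown here, the only guide to its effect is a number 8.7 percentage points lower from compound 1 to compound 2 (within the scatter), a step within the scatter. Because of that step, the expected step from compound 3 to compound 4 in this assay is a number 0.4 percentage points lower from compound 3 to compound 4 (within the scatter), which rests on a single pair and is therefore uncertain. Compound 4 is expected to give about 3%, with the estimate lying between -8% and 16%.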

Compound 4, percent growth inhibition at one concentration: 28.1%
Beside the measured number, compound 4's estimate is 25.1 percentage points below it, and the stated range ends below it.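

In this assay, the exchange of 4-chloro-3-nitrophenyl for 3-(trifluoromethyl)phenyl did not carry over from one core to the other. On the core of compound 1 it left the two numbers within the scatter, whereas on the other core it gave a number 24.7 percentage points higher from compound 3 to compound 4 (beyond the scatter), and the two steps do differ: the same change on two cores in this assay, a number 8.7 percentage points lower (within the scatter) from compound 1 to compound 2 and a number 24.7 percentage points higher (beyond the scatter) from compound 3 to compound 4, 33.4 percentage points apart, beyond the scatter of two such steps. Seen from the other direction, 1H-imidazol-2-yl in place of 1,3-thiazol-2-yl lowers the number with either group on the amide-type nitrogen, but the size of the drop depends on that group, with a number 36 percentage points lower from compound 2 to compound 4 (beyond the scatter) in the 3-(trifluoromethyl)phenyl pair: the same change on two cores in this assay, a number 69.4 percentage points lower (beyond the scatter) from compound 1 to compound 3 and a number 36 percentage points lower (beyond the scatter) from compound 2 to compound 4, 33.4 percentage points apart, beyond the scatter of two such steps. So in these four compounds the two changes do not simply add up, although this comparison rests on one pair per core and shows neither why the steps differ nor whether the same would hold for other groups.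

The compounds shown leave open how a phenyl group carrying an amine or a carboxylic acid on the amide-type nitrogen would behave on each core. They also leave open whether the gap between the two steps would persist at concentrations other than the single one tested.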